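The source may hold more compounds than are shown below. What is called first, only, known or untested is meant among the compounds shown, and "the series" means these compounds.

Measured so far in a functional assay for antagonist activity at Melanocortin receptor 4 (Homo sapiens), read by cAMP accumulation; on this read-out lower numbers stand for stronger inhibition and higher numbers for weaker inhibition:
compound 1 `CCN(CC)CCCC(C)/N=C(/N)NC(=O)c1cccc(F)c1CCc1ccc2ccccc2c1` gives 1800 nM
compound 2 `COc1ccc(Br)cc1CCc1c(F)cccc1C(=O)/N=C(\N)NCCCCN1CCCCC1` gives 70 nM
compound 3 `CCN(CC)CCCC(C)/N=C(/N)NC(=O)c1cccc(F)c1CCc1ccccc1Cl` gives only a limit of the assay, > 33000 nM

Compound 2 stands with the lowest of the two numbers actually reported; compound 1 comes next, with a clearly higher number. For the measured compounds named here, the single step between measured compounds, an at least 18-fold higher number from compound 1 to compound 3 (1.26 log units; beyond the scatter), changed the aryl end of the shared core, not the amine end. Compound 4 `COc1ccc(Br)cc1CCc1c(F)cccc1C(=O)/N=C(\N)NCCCN1CCN(C)CC1` differs from compound 2 at the amine end: 4-methylpiperazin-1-yl in place of (piperidin-1-yl)methyl on a saturated chain carbon, three bonds along the chain from an amine nitrogen. Going by the values given here, no measured step touches that part of the molecule, so compound 2 itself is the only anchor. Only a small step, a 2.1-fold higher number from compound 2 to compound 4 (0.33 log units; beyond the scatter), is expected, close to the usual scatter. Compound 4 is estimated at 150 nM in this assay, between 40 nM and 600 nM.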

Compound 4, half-maximal inhibitory concentration: 670 nM
Compound 4: the middle estimate sits 4.5-fold (0.65 log units) below what was measured; the measured number lies above the stated range.
By their numbers in this assay, from the lowest: compound 2; then compound 4; then compound 1. At a limit, above all of these: compound 3.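

For the compounds shown here, the amine end, which no earlier step touched, also moves the number in this assay: with the aryl end unchanged, 4-methylpiperazin-1-yl in place of (piperidin-1-yl)methyl brings a 9.6-fold higher number from compound 2 to compound 4 (0.98 log units; beyond the scatter). So a swap that keeps the heavy-atom count of the group still gives a modest step. Nothing measured here accounts for that step.

Going by these compounds, the 4-(piperidin-1-yl)butyl and 3-(4-methylpiperazin-1-yl)propyl ends differ in both chain and ring, so it remains open which of the two matters. A 4-(4-methylpiperazin-1-yl)butyl end would separate them.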